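Isopropoxy to cyclobutyloxy on compound 3

This account rests on a few compounds, and the source may have more. Where it says the series, first, only, none or still open, it means among the compounds named here.

In a functional assay on A549 cells (Homo sapiens) for antiproliferative activity, read by MTT assay, with a stated time of 48 h (a lower number here means a stronger inhibitor, a higher number a weaker inhibitor), compound 3 `COc1cc(-c2nnc3c(OC(C)C)cc(-c4ccc5c(ccn5C)c4)cn23)cc(OC)c1OC` gives 322 nM, within the scatter of the two other measured compounds. Of these, compound 2 `CCOc1cc(-c2ccc3c(ccn3C)c2)cn2c(-c3cc(OC)c(OC)c(OC)c3)nnc12` gives 334 nM. Compound 1 `COc1cc(-c2nnc3c(OC4CCC4)cc(-c4ccc5[nH]ccc5c4)cn23)cc(OC)c1OC`, which also carries cyclobutyloxy, gives 232 nM. Compound 4 `COc1cc(-c2nnc3c(OC4CCC4)cc(-c4ccc5c(ccn5C)c4)cn23)cc(OC)c1OC` has cyclobutyl in place of isopropyl on an oxygen on an aromatic ring. Going by the values given here, the only measured step at this oxygen, a 1.0-fold lower number from compound 2 to compound 3 (0.02 log units; within the scatter), stayed within the scatter. No step beyond the scatter is therefore expected in this assay, and no direction can be argued. The expected step is a 1.2-fold lower number from compound 3 to compound 4 (0.06 log units; within the scatter). The estimate for compound 4 is 280 nM, with an expected range from 140 nM to 560 nM.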

Compound 4, half-maximal inhibitory concentration: 176 nM
Beside the measured number, compound 4's estimate is 1.6-fold (0.20 log units) above it; the measured number falls inside the stated range.
By their numbers in this assay, from the lowest: compounds 4, 1, 3 and 2 (each within the scatter of the next).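

In this assay cyclobutyl on this oxygen, the first ring here, gives no step beyond the scatter from the open chains, isopropyl (a 1.8-fold lower number from compound 3 to compound 4 (0.26 log units; within the scatter)) or ethyl (a 1.9-fold lower number from compound 2 to compound 4 (0.28 log units; within the scatter)). With cyclobutyloxy held, methyl in place of hydrogen on the aromatic nitrogen also stays within the scatter (a 1.3-fold lower number from compound 1 to compound 4 (0.12 log units; within the scatter)). Nothing measured on these compounds offers an explanation for these steps.

Still open, going by these compounds, is whether any group on this oxygen moves the number beyond the scatter, for example a longer chain, an amine or a carboxylic acid.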